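Inverting one stereocentre of the ethyl compound

This account rests on a few compounds, and the source may have more. Where it says the series, first, only, none or still open, it means among the compounds named here.

In a functional assay on HOS cells (Homo sapiens) for antiproliferative activity, read by sulforhodamine B assay (a lower number here means a stronger inhibitor of growth, a higher number a weaker inhibitor of growth), compound 2 (`CC[C@@H]1O[C@H](COCc2ccccc2)[C@@H](OCc2ccccc2)[C@H](OCc2ccccc2)[C@H]1O`) gives 34200 nM and stands within the scatter of compound 1 (`O[C@H]1CO[C@H](COCc2ccccc2)[C@@H](OCc2ccccc2)[C@@H]1OCc1ccccc1`), which gives 37900 nM in the same read-out. Compound 3 (`CC[C@H]1O[C@H](COCc2ccccc2)[C@@H](OCc2ccccc2)[C@H](OCc2ccccc2)[C@H]1O`) has not yet been measured, and the change from compound 2 is the two compounds have the same atoms and bonds and differ only in configuration as drawn: 1 of 5 stereo elements differ; a stereocentre at a saturated ring carbon is drawn S in compound 2 and R in compound 3 with no other alteration: a stereocentre at a saturated ring carbon is drawn S in compound 2 and R in compound 3. Going by the values given here, the only measured step, a 1.1-fold lower number from compound 1 to compound 2 (0.04 log units; within the scatter) for ethyl in place of hydrogen on a saturated ring carbon, bears on this only indirectly. Among the compounds with values here, no measured pair differs in configuration alone, so the data favour no direction. The expected 1.0-fold lower number from compound 2 to compound 3 (0.00 log units; within the scatter) therefore stays within the scatter. Compound 3 is estimated at 34000 nM with an expected range from 14000 nM to 80000 nM in this estimate.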

Compound 3, concentration for 50% growth inhibition: > 50000 nM
Compound 3: no number, only a limit; the forecaster's own chance of this, stated with the estimate: 5%; at least 1.4-fold (0.16 log units) between middle value and limit.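

In this assay compound 3 gives > 50000 nM, which is a limit and not a number. The only pair shown that isolates configuration at this saturated ring carbon gives an at least 1.4-fold higher number from compound 2 to compound 3 (0.16 log units; that floor lies within the scatter), so only a floor is known for the effect of this inversion, and the true gap may or may not exceed the scatter: the fact that compounds 2 and 3 differ only in the configuration as drawn. The reading against the compound without ethyl is an at least 1.3-fold higher number from compound 1 to compound 3 (0.12 log units; that floor lies within the scatter), so neither drawn configuration of the ethyl is shown to shift growth inhibition beyond the scatter.

The compounds shown leave open whether a measured number for compound 3 would lie beyond the scatter of compound 2. They also leave open whether configuration at this carbon would count for more with a longer chain or an amine in place of the ethyl.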